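This account rests on a few compounds, and the source may have more. Where it says the series, first, only, none or still open, it means among the compounds named here.

Compound 1 `COc1ccc(S(=O)(=O)Nc2ccc(-c3nc4ccccc4o3)cc2)cc1`: in an assay on isolated protein for inhibition of malate dehydrogenase, mitochondrial (Sus scrofa), with stated times of 45 min and 30 min (on this read-out lower numbers stand for stronger inhibition and higher numbers for weaker inhibition), compound 1 gives > 63000 nM, which is a limit of the assay and not a number.
Compound 2 `Cc1cccc(S(=O)(=O)Nc2ccc(-c3nc4ccccc4o3)cc2)c1`: in this assay compound 2 gives > 63000 nM, again a limit.
Compound 3 `C=Cc1ccc(S(=O)(=O)Nc2ccc(-c3nc4ccccc4o3)cc2)cc1`: in this assay compound 3 gives > 63000 nM, also a limit.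

Compound 3 therefore stands only at a limit, and the two further values are limits as well (the limit of > 63000 nM in this assay, at which 3 of the 3 values shown sit). Compound 4 `O=S(=O)(Nc1ccc(-c2nc3ccccc3o2)cc1)c1cccc(O)c1` differs from it in one place: 3-hydroxyphenyl in place of 4-vinylphenyl on a sulfonyl sulfur. The measured steps that bear on this change exchange the group on the sulfonyl sulfur or a substituent on its ring: a step that the two limits leave unreadable from compound 2 to compound 3, a step that the two limits leave unreadable from compound 1 to compound 2 and a step that the two limits leave unreadable from compound 1 to compound 3. None of them can be read in size, because every value involved sits at the same limit (the limit of > 63000 nM in this assay, at which 3 of the 3 values shown sit). The measured compounds thus give no sign of a step beyond the scatter in either direction, and the step of a number no higher from compound 3 to compound 4 (the limit leaves the size open) is expected to be flat. Compound 4 is estimated at 63000 nM, with a range from 20000 nM to 200000 nM, and it is expected most likely to be reported once more only as a limit.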

Compound 4, half-maximal inhibitory concentration: > 63000 nM
Compound 4 gave a limit, no number (the forecaster's own chance of this, stated with the estimate: 75%); the middle value sits exactly at the limit.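

The steps from compound 1, compound 2 and compound 3 to compound 4 cannot be read in size, because all four values are the same limit: the limit of > 63000 nM in this assay, at which 4 of the 4 values shown sit.

The compounds shown leave open whether any group on the sulfonyl sulfur differs from another in this assay.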